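This account rests on a few compounds, and the source may have more. Where it says the series, first, only, none or still open, it means among the compounds named here.

Going by the values given here, compound 2 `COc1cc(-c2cc(/C=C/C(=O)c3ccc(N)cc3)[nH]n2)cc(OC)c1OC` gives 67% in a functional assay on RXF 393 cells (Homo sapiens) for cytotoxicity, read by sulforhodamine B assay, with a stated time of 48 h, tested at 1 uM (on this read-out lower numbers stand for a stronger effect and higher numbers for a weaker effect at the one concentration tested), the lowest of the three numbers measured so far. Compound 3 `COc1ccc(C(=O)/C=C/c2cc(-c3cc(OC)c(OC)c(OC)c3)n[nH]2)cc1OC` gives 72%, a step of a number 5 percentage points higher from compound 2 to compound 3 (within the scatter). Among the compounds with values here, compound 1 `COc1ccc(-c2cc(/C=C/C(=O)c3ccc(N)cc3)[nH]n2)cc1` gives 78%, a number beyond the scatter from compound 2; the two structures differ in two methoxy groups on the same aromatic ring, a pair for which no single step is recorded.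

Compound 4 `COc1ccc(-c2cc(/C=C/C(=O)c3ccc(N)cc3)[nH]n2)cc1OC` is reached from compound 2 by the change (hydrogen in place of methoxy on an aromatic carbon). Within the data shown here, no measured step removes a methoxy group alone, so the only bearing comes from compound 1 and compound 2, whose values show that taking away two methoxy groups goes with a higher number. Compound 4 sits structurally between them, carrying one methoxy group fewer than compound 2 and one more than compound 1. The expected step is therefore a number 5 percentage points higher from compound 2 to compound 4 (within the scatter), small and upward. Compound 4 is expected to give about 72%, within a range from 62% to 82%.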

Compound 4, a percentage reported as activity, at one concentration (the size of the read-out at that concentration, not a potency): 94%
For compound 4 the middle estimate is 22 percentage points below the measured one; measured number outside the range, above it.
By their numbers in this assay, from the lowest: compounds 2, 3 and 1 (each within the scatter of the next, the first and the last beyond it); then compound 4.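

Hydrogen in place of methoxy at this carbon, meta to a large group, gives a number 27 percentage points higher from compound 2 to compound 4 (beyond the scatter) in this assay and so weakens the effect on the cells. The reverse swap on a ring with one methoxy fewer also gives a number 16 percentage points higher from compound 1 to compound 4 (beyond the scatter) and so also weakens the effect, which shows that what a methoxy group does here depends on the rest of the ring rather than adding up group by group. Nothing measured here explains this reversal.

A hydroxyl group or a fluorine atom on this carbon could show whether methoxy itself matters at this position. As far as these compounds go, it also remains open whether the same swap behaves alike when a 3,4-dimethoxyphenyl group replaces the 4-aminophenyl group on the carbonyl.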